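Dimethylamino for acetyl on a pyrazole series tested in cells

A few compounds are considered here, and "the series" means these few. Any claim that something is new, unique, unknown or untested is made for them only; others in the source may bear on it.

Measured compounds:
- compound 1 `COc1cc(C)cc(-c2c(-c3ccnc(-c4ccc(C(C)=O)cc4)c3)cnn2CC#N)c1`: 88%
- compound 2 `COc1cc(C)cc(-c2nn(CC#N)cc2-c2ccc(-c3cccc(C(C)=O)c3)nc2)c1`: 88%

Of the compounds shown here, two have been measured so far in a functional assay on PC-3 cells (Homo sapiens) for cytotoxicity, read by sulforhodamine B assay, with a stated time of 48 h, tested at 0.01 uM; a higher number here means a weaker effect of the compound at the concentration tested, a lower number a stronger effect. Compound 1 gives 88%, and compound 2 gives 88%. The two values are level at the digits shown, and no step between them is reported, so the numbers say only that both compounds leave most of the cells unaffected at the concentration tested. Compound 1 therefore stands with compound 2, with nothing to separate them beyond the scatter.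

Compound 3 `COc1cc(C)cc(-c2c(-c3ccnc(-c4ccc(N(C)C)cc4)c3)cnn2CC#N)c1` has not yet been measured. It differs from compound 1 in one place: dimethylamino in place of acetyl on an aromatic carbon

Going by the values given here, no measured pair with a single change exists here, so the size of this step cannot be read from the data. With both known compounds at a weak effect, compound 3 is expected to stay in that region, and the step of a number 2 percentage points lower from compound 1 to compound 3 (within the scatter) is estimated to be small, not beyond the scatter in either direction. Compound 3 is accordingly expected to give about 86%, within a range from 68% to 100%.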

Compound 3, a percentage reported as activity, at one concentration (the size of the read-out at that concentration, not a potency): 30%
Beside the measured number, compound 3's estimate is 56 percentage points above it; measured number outside the range, below it.
By their numbers in this assay, from the lowest: compound 3; then compounds 1 and 2 (each within the scatter of the next).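

In this assay, dimethylamino in place of acetyl gives a number 58 percentage points lower from compound 1 to compound 3 (beyond the scatter), which shows that this aromatic carbon, para to a large group, is a place where a single change can strongly alter the read-out, something the acetyl compounds alone could not reveal. The change is also a narrow one by the counts available: acetyl and dimethylamino have the same number of heavy atoms, hydrogen-bond donors and hydrogen-bond acceptors, and neither carries a net charge, so these counts do not distinguish the two groups even though the read-out does. Nothing in the available data explains why the swap has this effect.

The compounds shown leave open whether the gain is specific to dimethylamino or is shared by a primary amine, a methoxy group or a pyrrolidine ring at the same carbon. They also leave open whether dimethylamino would have a similar effect on the core of compound 2, and, as the read-out comes from one concentration, whether compound 3 would give a stronger or weaker effect at other concentrations.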